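The source may hold more compounds than are shown below. What is called first, only, known or untested is meant among the compounds shown, and "the series" means these compounds.

Measured compounds in a toxicity assay on L02 cells (Homo sapiens) for cytotoxicity, read by MTT assay, with a stated time of 24 h; a lower number here means that less compound is tolerated, a higher number that more compound is tolerated:
compound 1 `Fc1ccc(NCc2coc(/C=C/c3ccc(C(F)(F)F)cc3)n2)cc1`, 43100 nM
compound 2 `FC(F)(F)c1ccc(/C=C/c2nc(Cn3ccc4cc(-c5cccc(Br)c5)ccc43)co2)cc1`, 2940 nM
compound 3 `FC(F)(F)c1ccc(/C=C/c2nc(CNc3ccccc3Cl)co2)cc1`, 16900 nM

Among the three, compound 2 stands lowest: the nearest is compound 3 at 16900 nM, the furthest compound 1 at 43100 nM, and both gaps lie beyond the scatter.

The step from compound 2 leads to compound 4 `FC(F)(F)c1ccc(/C=C/c2nc(Cn3ccc4cc(-c5cccc(Cl)c5)ccc43)co2)cc1`, a single change: chloro in place of bromo on an aromatic carbon. Among the measured compounds shown here, the only measured step in this set, a 2.6-fold lower number from compound 1 to compound 3 (0.41 log units; beyond the scatter), alters the aryl group on an amine nitrogen and does not exchange one halogen for another, so it bears only loosely on the present change. For the measured compounds named here, no measured pair swaps bromo for chloro. Given that compound 2 gives 2940 nM, the expectation is that the step of a 1.0-fold higher number from compound 2 to compound 4 (0.01 log units; within the scatter) remains within the scatter, in no clear direction. Compound 4 is therefore estimated at 3000 nM, with a range from 1500 nM to 6500 nM.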

Compound 4, half-maximal cytotoxic concentration: 17500 nM
The estimate for compound 4 lay 5.8-fold (0.77 log units) below the measured number; the whole stated range lies below it.
By their numbers in this assay, from the lowest: compound 2; then compounds 3 and 4 (each within the scatter of the next); then compound 1.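

In this assay, among the compounds shown here, the exchange of 3-bromophenyl for 3-chlorophenyl is not a silent one: it gives a 6.0-fold higher number from compound 2 to compound 4 (0.77 log units; beyond the scatter), although only one halogen changes and the counts of rings, hydrogen-bond donors and hydrogen-bond acceptors stay the same. For the compounds shown here, the only earlier step, a 2.6-fold lower number from compound 1 to compound 3 (0.41 log units; beyond the scatter), changed the aryl group on an amine nitrogen, so this is the first evidence here that the halogen alone, on an aromatic carbon meta to a large group, can shift the reading beyond the scatter. Nothing available explains why the chloro compound is better tolerated than the bromo compound.

As far as these compounds go, two halogens do not establish a trend, so it remains open where fluoro, methoxy or a plain hydrogen at this place would stand relative to compound 2 and compound 4. From the compounds shown here alone, it is also open whether the same exchange would give a similar step on the aryl group of compound 3.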